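The source may report more compounds than this note shows. Statements on the series, on what has been measured and on what is new or still open speak of the compounds shown alone.

Measured in a functional assay on KB cells (Homo sapiens) for cytotoxicity; on this read-out lower numbers stand for stronger inhibition and higher numbers for weaker inhibition:
- Compound 1 `COc1ccc(S(=O)(=O)N2CCc3cccc(NC(=O)C(C)(C)C)c32)cc1`: 359 nM
- Compound 2 `COc1ccc(S(=O)(=O)N2CCc3cccc(NC(=O)c4ccc(F)cc4)c32)cc1`: 93 nM
- Compound 3 `COc1ccc(S(=O)(=O)N2CCc3cccc(NCc4ccccc4)c32)cc1`: > 10000 nM, a limit of the assay

Compound 3 stands at the limit of > 10000 nM in this assay, at which 1 of the 3 values shown sits, so it has a limit and no number. The next compound is compound 4 `COc1ccc(S(=O)(=O)N2CCc3cccc(N)c32)cc1`, with this change: hydrogen in place of benzyl on a nitrogen on an aromatic ring. In words, hydrogen takes the place of benzyl on a nitrogen on an aromatic ring, or benzylamino becomes amino.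

Going by the values given here, two measured steps bear on this nitrogen: an at least 27-fold higher number from compound 1 to compound 3 (1.44 log units; beyond the scatter) and an at least 100-fold higher number from compound 2 to compound 3 (2.03 log units; beyond the scatter). Both are large. They show that the acylated compounds carry much lower numbers than the benzyl compound, while the step between the two acyl groups is only modest: a 3.9-fold lower number from compound 1 to compound 2 (0.59 log units; beyond the scatter). Among the compounds with values here, no measured compound carries the free amino group, and compound 4 has no carbonyl on this nitrogen, so a full return to the level of compound 1 or compound 2 is not assumed.

A modest move towards a lower number is expected, and the expected step is an at least 5.0-fold lower number from compound 3 to compound 4 (0.69 log units; beyond the scatter). For compound 4 the estimated value is 2000 nM, with an expected range of 300 nM to 10000 nM.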

Compound 4, half-maximal inhibitory concentration: 2800 nM
Beside the measured number, compound 4's estimate is 1.4-fold (0.15 log units) below it; low and high end bracket the measured number.
By their numbers in this assay, from the lowest: compound 2; then compound 1; then compound 4. At a limit, above all of these: compound 3.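

Removing the benzyl group in this assay gives compound 4 a measurable number (an at least 3.5-fold lower number from compound 3 to compound 4 (0.55 log units; beyond the scatter)). The free amine still sits well short of both amides (a 7.8-fold higher number from compound 1 to compound 4 (0.89 log units; beyond the scatter); a 30-fold higher number from compound 2 to compound 4 (1.48 log units; beyond the scatter)), so at this nitrogen the two acyl groups go with the lowest numbers among the four compounds, and the benzyl group with the highest. Compound 3 is a limit and not a number, so its step to compound 4 is only a bound: the limit of > 10000 nM in this assay, at which 1 of the 4 values shown sits.

Still open, as far as these compounds go, is whether a small acyl group such as acetyl keeps the low numbers of the two amides, or whether a methyl on this nitrogen behaves like the free amine or like the benzyl compound. A urea or a sulfonamide on this nitrogen would show whether the carbonyl of the amide is what matters here.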